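A few compounds are considered here, and "the series" means these few. Any claim that something is new, unique, unknown or untested is made for them only; others in the source may bear on it.

Compound 2 `O=C(/C=C/c1cccc(NS(=O)(=O)c2ccc(Cl)cc2)c1)c1nc2ccccc2[nH]1` is the stronger of the two measured compounds in a functional assay on MCF7 cells (Homo sapiens) for antiproliferative activity, read by MTT assay, with a stated time of 48 h; a lower number here means a stronger inhibitor, a higher number a weaker inhibitor: compound 2 gives 3820 nM, while its amide counterpart compound 1 `O=C(Nc1cccc(/C=C/C(=O)c2nc3ccccc3[nH]2)c1)c1ccc(Cl)cc1` gives 8410 nM. Within the data shown here, the one measured step, a 2.2-fold lower number from compound 1 to compound 2 (0.34 log units; beyond the scatter), concerns only the sulfonyl in place of the carbonyl on the aniline nitrogen and says nothing about the distal aromatic ring.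

Compound 3 `Cc1ccc(S(=O)(=O)Nc2cccc(/C=C/C(=O)c3nc4ccccc4[nH]3)c2)cc1` carries exactly that untested change: methyl in place of chloro on an aromatic carbon, para to a large group, so that the (4-chlorophenyl)sulfonyl becomes a (4-methylphenyl)sulfonyl. Among the measured compounds shown here, no measured pair differs at this position, so no step in this assay bears on it directly. Both groups are single heavy atoms without donors or acceptors, and the rest of the molecule, including the sulfonamide link that set compound 2 apart from compound 1, is unchanged.

Compound 3 is therefore expected to stay close to compound 2, with a 1.1-fold higher number from compound 2 to compound 3 (0.04 log units; within the scatter) not beyond the scatter, in either direction. The estimate for compound 3 in this assay is 4200 nM, within the range 1500 nM to 12000 nM.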

Compound 3, half-maximal inhibitory concentration: 3220 nM
The estimate for compound 3 lay 1.3-fold (0.12 log units) above the measured number; the measured number falls inside the stated range.
By their numbers in this assay, from the lowest: compounds 3 and 2 (each within the scatter of the next); then compound 1.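

In this assay, the ring carried by the sulfonyl now has its first measured change: methyl in place of chloro, on an aromatic carbon para to a large group, gives a 1.2-fold lower number from compound 2 to compound 3 (0.07 log units; within the scatter), so this exchange of one heavy atom for another does not separate compound 2 from compound 3. Compound 3 also stands apart from the amide compound 1, with a 2.6-fold lower number from compound 1 to compound 3 (0.42 log units; beyond the scatter), but that step replaces the whole (4-chlorophenyl)carbonyl with (4-methylphenyl)sulfonyl and cannot divide the difference between the link and the ring substituent. No measurement at hand accounts for the matching numbers of the chloro and methyl compounds.

Because only chloro and methyl are compared at this position, the compounds shown do not tell whether an amine, a carboxylic acid or a methoxy group there would move the number beyond the scatter. They also leave open how a (4-methylphenyl)carbonyl on the same nitrogen would read, the one partner that would isolate the link in the methyl series.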